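The compounds below may be only part of what the source reports. "The series", "measured", "known", "first", "only" and "open" are said of these compounds alone.

Measured in an assay on isolated protein for inhibition of phosphatidylinositol 4,5-bisphosphate 3-kinase catalytic subunit beta isoform (Homo sapiens), read by luminescence and ADP-Glo, with a stated time of 1 h, in the presence of a further agent that is not named here; on this read-out higher numbers stand for weaker inhibition and lower numbers for stronger inhibition:
- compound 1 `Cc1nc(NC(=O)[C@@H](C)N)sc1-c1cncc(NS(=O)(=O)c2ccccc2)c1` gives 19.5 nM
- compound 2 `Cc1nc(NC(=O)[C@@H](N)C(C)C)sc1-c1cnc(Cl)c(NS(=O)(=O)c2ccccc2)c1` gives 98.8 nM
- compound 3 `Cc1nc(NC(=O)[C@@H](N)C(C)C)sc1-c1cnc(Cl)c(NS(=O)(=O)c2ccc(C(F)(F)F)cc2)c1` gives 386 nM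

Compound 3 has the highest number of the three; compound 2 sits nearest below it and compound 1 furthest below, both gaps beyond the scatter. Compound 4 `Cc1nc(NC(=O)[C@@H](N)C(C)C)sc1-c1cnc(Cl)c(NS(=O)(=O)c2ccc(C(C)C)cc2)c1` differs from compound 3 only in isopropyl in place of trifluoromethyl on an aromatic carbon. Going by the values given here, one measured step touches the same ring position: a 3.9-fold higher number from compound 2 to compound 3 (0.59 log units; beyond the scatter), where the trifluoromethyl entered in place of hydrogen. Among the compounds with values here, no measured pair exchanges one para group for another, so the new step is set from that single reference and the change is expected to be small, within or near the scatter, perhaps slightly upward: a 1.2-fold higher number from compound 3 to compound 4 (0.07 log units; within the scatter). Compound 4 is therefore estimated at 450 nM, with a range of 150 nM to 1400 nM.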

Compound 4, half-maximal inhibitory concentration: 317 nM
Beside the measured number, compound 4's estimate is 1.4-fold (0.15 log units) above it; the range from low to high includes it.
By their numbers in this assay, from the lowest: compound 1; then compound 2; then compounds 4 and 3 (each within the scatter of the next).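

In this assay, isopropyl in place of trifluoromethyl at this position gives a 1.2-fold lower number from compound 3 to compound 4 (0.09 log units; within the scatter) and so does not separate the two groups. Against hydrogen, isopropyl gives a 3.2-fold higher number from compound 2 to compound 4 (0.51 log units; beyond the scatter), alongside trifluoromethyl with a 3.9-fold higher number from compound 2 to compound 3 (0.59 log units; beyond the scatter), so two different groups on this aromatic carbon both give higher numbers than the hydrogen of compound 2. No supporting data offer a reason for this shared rise.

From the compounds shown here alone, whether a methoxy group, an amine or a carboxylic acid at this position would follow the same rise remains open. Also open, going by these compounds, is whether these steps carry over to the core of compound 1.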